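The compounds below may be only part of what the source reports. "The series", "measured", "known", "first", "only" and "open" are said of these compounds alone.

Measured so far in a functional assay on MCF7 cells (Homo sapiens) for inhibition, with a stated time of 72 h; a lower number here means a stronger inhibitor, a higher number a weaker inhibitor:
- compound 1 `NC1CCC(Nc2nc(NCc3ccc(-c4ccccc4)cc3)c3ncn(C4CCCC4)c3n2)CC1` gives 583 nM
- compound 2 `NC1CCC(Nc2nc(NCc3ccc(-c4cccc(F)c4)cc3)c3ncn(C4CCCC4)c3n2)CC1` gives 293 nM

Among the measured compounds shown here, compound 2 stands at 293 nM, and compound 1 is its only measured neighbour. For the measured compounds named here, the one measured step, a 2.0-fold lower number from compound 1 to compound 2 (0.30 log units; within the scatter), leaves the two compounds unseparated.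

Next in the series is compound 3 `NC1CCC(Nc2nc(NCc3ccc(-c4ccco4)cc3)c3ncn(C4CCCC4)c3n2)CC1`, with furan-2-yl in place of 3-fluorophenyl on an aromatic carbon, para to a large group. The counted change is furan-2-yl in place of 3-fluorophenyl on an aromatic carbon.

Going by the values given here, no measured step exchanges one aromatic ring for another, so the evidence is indirect. Among the compounds with values here, the only step that bears on this position is the fluoro in place of hydrogen on an aromatic carbon, a 2.0-fold lower number from compound 1 to compound 2 (0.30 log units; within the scatter), and it is small. On that basis, no shift beyond the scatter is expected in this assay, and the data support no firm direction. The expected step is a 1.4-fold higher number from compound 2 to compound 3 (0.14 log units; within the scatter). From the compounds shown here alone, the range is kept wide, as the ring exchange itself is untested.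

The estimated value for compound 3 is 400 nM, with an expected range from 150 nM to 1000 nM.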

Compound 3, half-maximal inhibitory concentration: 85 nM
The estimate for compound 3 lay 4.7-fold (0.67 log units) above the measured number, outside the stated range (below it).
By their numbers in this assay, from the lowest: compound 3; then compounds 2 and 1 (each within the scatter of the next).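

In this assay, this position, on an aromatic carbon para to a large group, now shows a change beyond the scatter: furan-2-yl in place of 3-fluorophenyl gives a 3.4-fold lower number from compound 2 to compound 3 (0.54 log units; beyond the scatter). Furan-2-yl in place of phenyl points the same way and gives a 6.9-fold lower number from compound 1 to compound 3 (0.84 log units; beyond the scatter), whereas the earlier fluoro in place of hydrogen gave a 2.0-fold lower number from compound 1 to compound 2 (0.30 log units; within the scatter), which stays within the scatter, so exchanging the whole ring separates these compounds where the added fluoro did not. The entering ring differs from the rings it replaces in size, in its oxygen and in its hydrogen-bond acceptor all at once, and nothing available here explains the gain or assigns it to any one of these differences.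

Open, from the compounds shown here alone, is whether the oxygen itself matters, which a thiophen-2-yl ring, with sulfur in the oxygen's place, could help to show, and whether its placement matters, which a furan-3-yl ring could address. A methyl group on the furan ring would show whether this position tolerates further substitution on the smaller ring, while the reach of the result beyond this assay also remains undefined.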